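The compounds below may be only part of what the source reports. "The series", "measured", "known", "first", "only" and "open" are said of these compounds alone.

Going by the values given here, only two compounds sharing one core have numbers so far. In a functional assay on A549 cells (Homo sapiens) for cytotoxicity, read by MTT assay, with a stated time of 48 h (a lower number here means a stronger inhibitor, a higher number a weaker inhibitor), compound 1 `C=C1C(=O)O[C@H]2CC3=C[C@H](C/C(C)=C/[C@@H](OC(=O)c4ccc(-c5ccccc5)cc4)[C@H]12)OC3=O` gives 4600 nM and compound 2 `C=C1C(=O)O[C@H]2CC3=C[C@H](C/C(C)=C/[C@@H](OC(=O)/C=C/c4ccccc4)[C@H]12)OC3=O` gives 4800 nM. These two values lie within the usual scatter of repeated measurements, so neither compound can be ranked above the other, and compound 2 stands level with compound 1 on the evidence available.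

The next compound to be tested is compound 3 `C=C1C(=O)O[C@H]2CC3=C[C@H](C/C(C)=C/[C@@H](OC(=O)CCCCC)[C@H]12)OC3=O`, which departs from compound 2 through one change: pentyl in place of 2-phenylethenyl on a carbonyl carbon. Among the compounds with values here, no measured pair shows what a swap of this kind does, so the expectation is loose and starts from the only anchor available, compound 2 at 4800 nM. A modest move towards a higher number, meaning a somewhat weaker inhibitor, is expected, and it may not clear the scatter. The expected change is a 1.4-fold higher number from compound 2 to compound 3 (0.13 log units; within the scatter). For compound 3 the estimated value in this assay is 6500 nM, with an expected range from 2500 nM to 17000 nM.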

Compound 3, half-maximal inhibitory concentration: > 10000 nM
Compound 3 gave a limit, no number (the forecaster's own chance of this, stated with the estimate: 8%); middle value at least 1.5-fold (0.18 log units) from the limit.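

In this assay compound 3 reads > 10000 nM, which is a limit of the assay and not a number. Even so, this position clearly responds to what it carries: pentyl in place of 2-phenylethenyl on a carbonyl carbon gives an at least 2.0-fold higher number from compound 2 to compound 3 (0.31 log units; beyond the scatter), whereas compounds 1 and 2, which both carry aromatic rings here, could not be separated from each other. The step can be read only as a minimum, because compound 3 sits at the limit of what the assay reports: the limit of > 10000 nM in this assay, at which 1 of the 3 values shown sits.

The swap removes an aromatic ring and a double bond and also changes the size of the group, so the three compounds shown cannot say which of these differences matters. A 2-phenylethyl group, which keeps the ring without the double bond, would help to separate them, while a longer chain such as octyl or a chain ending in an amine or a carboxylic acid would show whether any non-aromatic group can be tolerated at this position.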